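Removing a Chloro Group from a Cytotoxicity Series

A few compounds are considered here, and "the series" means these few. Any claim that something is new, unique, unknown or untested is made for them only; others in the source may bear on it.

Of the compounds shown here, three sharing one core have been tested in an ADME assay on MT4 cells (Homo sapiens) for cytotoxicity, read by MTT assay, with a stated time of 5 days; on this read-out lower numbers stand for higher toxicity in this test and higher numbers for lower toxicity in this test. Compound 1 `N#Cc1ccc(Nc2nccc(OCc3cccc(Cl)c3)n2)cc1` gives 153000 nM. Compound 3 `N#Cc1ccc(Nc2nccc(OCc3ccccc3C(F)(F)F)n2)cc1` gives 173000 nM, and compound 2 `Cc1cccc(COc2ccnc(Nc3ccc(C#N)cc3)n2)c1` gives 30000 nM. Compound 1 thus stands second highest of the three numbers, with compound 3 within the scatter of it, while the step of a 5.1-fold lower number from compound 1 to compound 2 (0.71 log units; beyond the scatter) shows that a methyl in place of chloro on an aromatic carbon brings the number down, meaning more toxicity in this test.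

Compound 4 `N#Cc1ccc(Nc2nccc(OCc3ccccc3)n2)cc1` has not yet been measured. Its difference from compound 1 is hydrogen in place of chloro on an aromatic carbon. Among the measured compounds shown here, the only measured step at the same position is the one from compound 1 to compound 2, where the chloro was exchanged for methyl rather than for hydrogen; no measured pair shows the chloro removed outright. That step was modest, and compound 3 lies within the scatter of compound 1. A small downward step in this assay is therefore expected, or none beyond the scatter, and the expected step is a 1.4-fold lower number from compound 1 to compound 4 (0.14 log units; within the scatter). Compound 4 is estimated at 110000 nM, within a range from 45000 nM to 280000 nM.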

Compound 4, half-maximal cytotoxic concentration: 13000 nM
Estimate against measurement, compound 4: 8.5-fold (0.93 log units) above; the whole stated range lies above it.
By their numbers in this assay, from the lowest: compound 4; then compound 2; then compounds 1 and 3 (each within the scatter of the next).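

Removing the chloro outright does far more than exchanging it for methyl: in this assay hydrogen in its place gives a 12-fold lower number from compound 1 to compound 4 (1.07 log units; beyond the scatter) and so puts the unsubstituted benzyl group at the toxic end of this small set. Hydrogen in place of trifluoromethyl tells the same story, with a 13-fold lower number from compound 3 to compound 4 (1.12 log units; beyond the scatter) as the step. Even methyl keeps the number above that of the bare ring, with a 2.3-fold lower number from compound 2 to compound 4 (0.36 log units; beyond the scatter) as a smaller step, so all three groups on this ring carry higher numbers than hydrogen, and none of the compounds goes against this.

Going by these compounds, whether a methoxy group or an amine on the same ring would also raise the number remains open. What lies behind these differences also remains open, since no measurement shown here bears on it.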